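A few compounds are considered here, and "the series" means these few. Any claim that something is new, unique, unknown or untested is made for them only; others in the source may bear on it.

Compound 1 `CN1CC[C@@H](c2ccc(Cl)cc2)[C@H](C(=O)NCc2ccc(CNC(=O)/C=C/c3ccc(Cl)cc3)cc2)C1` was tested in an assay on a subcellular fraction from brain for inhibition of sodium-dependent dopamine transporter (Rattus norvegicus); on this read-out higher numbers stand for weaker inhibition and lower numbers for stronger inhibition. For compound 1 the result is only a limit of the assay, > 2000 nM, and not a measured number. A second compound, compound 2 `CN1CC[C@@H](c2ccc(Cl)cc2)[C@H](C(=O)NCc2ccc(CNC(=O)[C@@H]3CN(C)CC[C@H]3c3ccc(Cl)cc3)cc2)C1`, gives 2270 nM in this assay. Compound 3 `CN1CC[C@@H](c2ccc(Cl)cc2)[C@H](C(=O)NCc2ccc(CNC(=O)c3cccc(C(F)(F)F)c3)cc2)C1` differs from compound 1 in a single place: 3-(trifluoromethyl)phenyl in place of 2-(4-chlorophenyl)ethenyl on a carbonyl carbon. For the measured compounds named here, because compound 1 sits at the limit of > 2000 nM in this assay, at which 1 of the 2 values shown sits, no measured step can be drawn from it. The step from compound 1 to compound 3 is expected to be a step that the limit leaves unreadable from compound 1 to compound 3, nothing beyond the usual scatter. Compound 3 is therefore expected to give about 2500 nM in this assay, most plausibly between 800 nM and 8000 nM.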

Compound 3, inhibition constant: > 5000 nM
Compound 3 was reported as a limit; the forecaster's own chance of this, stated with the estimate: 55%; middle value at least 2.0-fold (0.30 log units) away from the limit.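

For the compounds shown here, compound 1 and compound 3 are each reported only as a limit in this assay, so no step between them can be read. The compounds shown leave open how far inhibition differs between 2-(4-chlorophenyl)ethenyl and 3-(trifluoromethyl)phenyl on the carbonyl carbon.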